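A few compounds are considered here, and "the series" means these few. Any claim that something is new, unique, unknown or untested is made for them only; others in the source may bear on it.

Compound 1 `COc1ccc(S(=O)(=O)N2CCc3cccc(-c4ccco4)c32)cc1` stands at the highest of the two numbers measured in a functional assay on NCI-H460 cells (Homo sapiens) for inhibition, with a stated time of 72 h (a lower number here means a stronger inhibitor, a higher number a weaker inhibitor), where compound 1 gives 94.5 nM. Its nearest neighbour is compound 2 `COc1ccc(S(=O)(=O)N2CCc3cccc(-c4cccnc4)c32)cc1`, which in this assay gives 89.6 nM. The step of a 1.1-fold lower number from compound 1 to compound 2 (0.02 log units; within the scatter) is the only one measured, and it bears on the change to compound 3 `COc1ccc(S(=O)(=O)N2CCc3cccc(-c4ccccc4)c32)cc1`, in which the same group on the aromatic carbon is exchanged once more: phenyl in place of furan-2-yl on an aromatic carbon. Since that measured exchange moved the number only within the scatter, no step beyond the scatter is expected for compound 3, the expected step being a 1.1-fold lower number from compound 1 to compound 3 (0.02 log units; within the scatter). Compound 3 is estimated at 90 nM, within 40 nM to 200 nM.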

Compound 3, half-maximal inhibitory concentration: 213 nM
Estimate against measurement, compound 3: 2.4-fold (0.37 log units) below; measured number outside the range, above it.
By their numbers in this assay, from the lowest: compounds 2 and 1 (each within the scatter of the next); then compound 3.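

In this assay the exchange for phenyl gives a 2.3-fold higher number from compound 1 to compound 3 (0.35 log units; beyond the scatter) and the exchange of pyridin-3-yl for phenyl gives a 2.4-fold higher number from compound 2 to compound 3 (0.38 log units; beyond the scatter) so this aromatic carbon does not accept every aromatic ring alike. Among these three compounds, furan-2-yl and pyridin-3-yl lie within the scatter of each other, and only the all-carbon phenyl stands apart. Nothing available explains this difference.

Whether the hetero atom itself accounts for the gap remains open. Also open, as far as these compounds go, is how this position responds to a non-aromatic group such as morpholine, an amine or a short alkyl chain.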